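The source may report more compounds than this note shows. Statements on the series, on what has been measured and on what is new or still open speak of the compounds shown alone.

Compound 2 `O=C(C1=C(Nc2ccccc2)C(=O)N(CCCn2ccnc2)C1c1ccc(Br)cc1)c1ccccc1` carries an anilino group on the shared core, where compound 1 `CCCCOC1=C(C(=O)c2ccccc2)C(c2ccc(Br)cc2)N(CCCn2ccnc2)C1=O` carries a butoxy group. In a functional assay on U2OS cells (Homo sapiens) for antiproliferative activity, read by MTT assay, with a stated time of 72 h (on this read-out lower numbers stand for stronger inhibition and higher numbers for weaker inhibition), compound 1 gives 32400 nM and compound 2 gives 25700 nM; the step of a 1.3-fold lower number from compound 1 to compound 2 (0.10 log units; within the scatter) lies within the scatter, so on the numbers shown compound 2 stands alongside compound 1 with nothing separating them. Compound 3 `O=C(C1=C(Nc2ccc(OC(F)(F)F)cc2)C(=O)N(CCCn2ccnc2)C1c1ccc(Br)cc1)c1ccccc1` differs from compound 2 by trifluoromethoxy in place of hydrogen on an aromatic carbon, the anilino becoming (4-(trifluoromethoxy)phenyl)amino. Going by the values given here, no measured step touches this ring: the single step known, from compound 1 to compound 2, concerns the group on the double-bonded ring carbon and stayed within the scatter, so it offers no guide to the direction here. The expectation is therefore a step of a 1.7-fold lower number from compound 2 to compound 3 (0.23 log units; within the scatter) that need not leave the scatter. The estimate for compound 3 in this assay is 15000 nM, within 4000 nM to 50000 nM.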

Compound 3, half-maximal inhibitory concentration: 11500 nM
The estimate for compound 3 lay 1.3-fold (0.12 log units) above the measured number; low and high end bracket the measured number.
By their numbers in this assay, from the lowest: compound 3; then compounds 2 and 1 (each within the scatter of the next).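

In this assay the ring of the anilino group proves responsive: trifluoromethoxy in place of hydrogen, on an aromatic carbon para to a large group, gives a 2.2-fold lower number from compound 2 to compound 3 (0.35 log units; beyond the scatter) and so leaves the scatter, as the exchange of butoxy for anilino alone did not. The (4-(trifluoromethoxy)phenyl)amino group in place of butoxy gives a 2.8-fold lower number from compound 1 to compound 3 (0.45 log units; beyond the scatter) and thus a separation from the butoxy compound that is also modest in size. Nothing available accounts for either shift.

With one substituent shown on this ring, the compounds leave open whether the gain belongs to trifluoromethoxy itself or would also appear with methoxy, trifluoromethyl or a single fluorine atom. On these data alone, how a carboxylic acid or an amine at the same place would read also remains open.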